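Replacing a bare sulfonamide amine with a thiomorpholine ring

The source may hold more compounds than are shown below. What is called first, only, known or untested is meant among the compounds shown, and "the series" means these compounds.

Compound 1 `CCN(CC)S(=O)(=O)c1ccc(NC(=O)C(C)(O)C(F)(F)F)cc1` gives 810 nM in an assay on a protein complex (Cavia porcellus) with sulfonylurea receptors; K-ATP channels (Homo sapiens) as the target; on this read-out higher numbers stand for weaker inhibition and lower numbers for stronger inhibition.
Compound 2 `CC(O)(C(=O)Nc1ccc(-c2nn[nH]n2)cc1)C(F)(F)F` gives > 30000 nM in this assay, which is a limit of the assay rather than a number.
Compound 3 `CC(O)(C(=O)Nc1ccc(S(N)(=O)=O)cc1)C(F)(F)F` gives 12800 nM in this assay.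

Of the two numbers, compound 3 stands highest, so it is the weaker inhibitor; the nearest number lies lower by a 16-fold higher number from compound 1 to compound 3 (1.20 log units; beyond the scatter). Compound 4 `CC(O)(C(=O)Nc1ccc(S(=O)(=O)N2CCSCC2)cc1)C(F)(F)F` is not yet measured and differs from compound 3 by thiomorpholin-4-yl in place of amino on a sulfonyl sulfur. Among the compounds with values here, the only measured step that bears on this is a 16-fold higher number from compound 1 to compound 3 (1.20 log units; beyond the scatter), where amino took the place of diethylamino on the sulfonyl sulfur and the number rose sharply. Putting a two-carbon-armed ring amine back onto that sulfur is expected to reverse this move, giving a large fall in the number, a 14-fold lower number from compound 3 to compound 4 (1.15 log units; beyond the scatter), that is, stronger inhibition. Compound 4 is therefore estimated at 900 nM, with a likely range from 250 nM to 3500 nM.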

Compound 4, half-maximal inhibitory concentration: 4580 nM
Estimate against measurement, compound 4: 5.1-fold (0.71 log units) below, outside the stated range (above it).
By their numbers in this assay, from the lowest: compound 1; then compound 4; then compound 3. At a limit, above all of these: compound 2.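

In this assay thiomorpholin-4-yl on the sulfonyl sulfur gives back only part of what amino loses, with a 2.8-fold lower number from compound 3 to compound 4 (0.45 log units; beyond the scatter) as the gain. The ring still falls short of diethylamino, with a 5.7-fold higher number from compound 1 to compound 4 (0.75 log units; beyond the scatter) as the remaining gap, so among these compounds, carbon groups on that sulfonamide nitrogen are not interchangeable. Nothing measured here accounts for the difference between the ring and the open chains.

On these data alone, whether a piperidine ring, a morpholine ring or a dimethylamino group on the same sulfur would come closer to compound 1 stays open.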